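This account rests on a few compounds, and the source may have more. Where it says the series, first, only, none or still open, it means among the compounds named here.

Measured in a functional assay on HepG2 cells (Homo sapiens) for inhibition, read by sulforhodamine B assay, with a stated time of 72 h; a lower number here means a stronger inhibitor, a higher number a weaker inhibitor:
- compound 1 `C[C@H](Nc1ncnc2[nH]cnc12)c1nn(-c2cccnc2)c2ccc(F)cc12`: 41900 nM
- compound 2 `Cc1ccc2c(c1)c([C@H](C)Nc1ncnc3[nH]cnc13)nn2-c1cccnc1`: > 40000 nM, a limit of the assay and not a number
- compound 3 `C[C@H](Nc1ncnc2[nH]cnc12)c1nn(-c2cccc(F)c2)c2cc(F)ccc12`: 32300 nM

Compound 3, at 32300 nM, stands within the scatter of compound 1, at 41900 nM. Compound 4 `C[C@H](Nc1ncnc2[nH]cnc12)c1nn(-c2cc(F)cc(F)c2)c2cc(F)ccc12` carries one change from compound 3: fluoro in place of hydrogen on an aromatic carbon. This is fluoro in place of hydrogen on an aromatic carbon, taking 3-fluorophenyl to 3,5-difluorophenyl. Going by the values given here, the only measured step is a step that the limit leaves unreadable from compound 1 to compound 2. It concerns methyl in place of fluoro, so it sets no size for this change. In this assay, no shift beyond the scatter is therefore expected, and compound 3 at 32300 nM remains the anchor. The estimated move is a 1.1-fold lower number from compound 3 to compound 4 (0.03 log units; within the scatter). For compound 4 the expected value is 30000 nM, with an estimated range of 14000 nM to 60000 nM.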

Compound 4, half-maximal inhibitory concentration: 22100 nM
Beside the measured number, compound 4's estimate is 1.4-fold (0.13 log units) above it; low and high end bracket the measured number.
By their numbers in this assay, from the lowest: compounds 4, 3 and 1 (each within the scatter of the next).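

In this assay, fluoro in place of hydrogen on the aromatic carbon meta to a fluoro group gives the first readable step among these compounds: a 1.5-fold lower number from compound 3 to compound 4 (0.16 log units; within the scatter). Taking 3-fluorophenyl to 3,5-difluorophenyl therefore leaves the value within the scatter, so this position accepts a second fluoro without a measurable shift. Nothing measured here bears on a cause for this step.

From the compounds shown here alone, whether a larger group at this position, such as methoxy, an amine or a carboxylic acid, would move the number beyond the scatter remains open.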